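From Ethoxy to Dimethylamino on a Shared Core

The compounds below may be only part of what the source reports. "The series", "measured", "known", "first", "only" and "open" are said of these compounds alone.

In an ADME assay on L6 cells (Rattus norvegicus) for cytotoxicity, read by resazurin assay, with a stated time of 72 h (a higher number here means a weaker inhibitor, a lower number a stronger inhibitor), three compounds sharing one core have been measured so far. Compound 1 (`CCc1ccc(C(=O)NC(=O)c2ccccc2O)cc1`) carries ethyl and gives 70 ug/mL here. Compound 2 (`CC(C)(C)c1ccc(C(=O)NC(=O)c2ccccc2O)cc1`) carries tert-butyl and gives 2.3 ug/mL here. Compound 3 (`CCOc1ccc(C(=O)NC(=O)c2ccccc2O)cc1`) carries ethoxy and gives 17 ug/mL and so holds the middle place among the three numbers.

The next compound, compound 4 (`CN(C)c1ccc(C(=O)NC(=O)c2ccccc2O)cc1`), has dimethylamino in place of ethoxy on an aromatic carbon. Among the measured compounds shown here, all the measured steps change the group at this same place. Moving from ethyl to ethoxy gave a 4.1-fold lower number from compound 1 to compound 3 (0.61 log units; beyond the scatter) and counts as modest. Moving from tert-butyl to ethoxy gave a 7.4-fold higher number from compound 2 to compound 3 (0.87 log units; beyond the scatter) and is also modest. Only the swap of ethyl for tert-butyl, a 30-fold lower number from compound 1 to compound 2 (1.48 log units; beyond the scatter), is large. For the measured compounds named here, no measured step replaces ethoxy with dimethylamino, so these steps only suggest how far the number might move, and they give no direction. A small step is therefore expected in this assay, and the estimated change is a 1.2-fold higher number from compound 3 to compound 4 (0.07 log units; within the scatter) and would stay within the usual scatter, though a modest step either way remains possible. The estimate for compound 4 is 20 ug/mL (expected range 6 ug/mL to 60 ug/mL).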

Compound 4, half-maximal inhibitory concentration: 54 ug/mL
For compound 4 the middle estimate is 2.7-fold (0.43 log units) below the measured one, within the range that was stated.
By their numbers in this assay, from the lowest: compound 2; then compound 3; then compounds 4 and 1 (each within the scatter of the next).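

In this assay, ethoxy and dimethylamino have the same heavy-atom count, the same hydrogen-bond donor and acceptor counts and no net charge, yet exchanging one for the other still moves the number beyond the usual scatter (a 3.2-fold higher number from compound 3 to compound 4 (0.50 log units; beyond the scatter)). Those simple counts therefore do not settle the result at this position, on an aromatic carbon para to a large group, since two groups that match on all of them still read differently. Dimethylamino cannot be told apart from ethyl here (a 1.3-fold lower number from compound 1 to compound 4 (0.11 log units; within the scatter)) and lies far from tert-butyl (a 23-fold higher number from compound 2 to compound 4 (1.37 log units; beyond the scatter)), while no measurement is at hand that would explain why these groups separate as they do.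

The compounds shown leave open whether the much lower number of compound 2 belongs to tert-butyl alone or would also appear with another branched group, such as isopropyl or cyclopropyl. They also leave open how a methoxy group, a primary amine or a longer chain such as n-butyl would read at this same place, and whether these steps would hold on a different core.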